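The source may hold more compounds than are shown below. What is called first, only, known or untested is meant among the compounds shown, and "the series" means these compounds.

Measured in a functional assay on L5178Y cells (Mus musculus) for inhibition, read by MTT assay, with a stated time of 24 h; on this read-out lower numbers stand for stronger inhibition and higher numbers for weaker inhibition:
- Compound 1 `COc1cccc(/C=N/N=C2\C[C@@H](c3ccc(O)cc3)Oc3cc(OC)cc(O)c32)c1` gives >= 11300 nM (a limit)
- Compound 2 `COc1cc(O)c2c(c1)O[C@H](c1ccc(O)cc1)C/C2=N\NC(=O)c1ccc(C(F)(F)F)cc1` gives >= 11300 nM (a limit)

Compound 2 has no number, only the limit of >= 11300 nM in this assay, at which 2 of the 2 values shown sit, and so no rank within the series. The next change leads to compound 3 `COc1cc(O)c2c(c1)O[C@H](c1ccc(O)cc1)C/C2=N\NC(=O)c1cccs1`, with thiophen-2-yl in place of 4-(trifluoromethyl)phenyl on a carbonyl carbon as the counted difference. Within the data shown here, no measured step shows what such a change does. An estimated step that the limit leaves unreadable from compound 2 to compound 3 in this assay is expected to stay within the scatter. That expectation rests on compound 2 with its limit >= 11300 nM as the only anchor. For compound 3 the expected value is 14000 nM with a range of 6000 nM to 40000 nM and a report as a limit is likely.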

Compound 3, half-maximal inhibitory concentration: 9400 nM
Compound 3: the middle estimate sits 1.5-fold (0.17 log units) above what was measured; low and high end bracket the measured number.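

Among these compounds, with thiophen-2-yl on the carbonyl carbon, compound 3 gives the first actual number in this assay, while the other compounds stay at a limit: the limit of >= 11300 nM in this assay, at which 2 of the 3 values shown sit. The exchange of groups reads as an at least 1.2-fold lower number from compound 2 to compound 3 (0.07 log units; that floor lies within the scatter), and the larger change on the double-bonded nitrogen reads as an at least 1.2-fold lower number from compound 1 to compound 3 (0.07 log units; that floor lies within the scatter). Going by these compounds, both are floors, so the true size of either step stays unknown.

Still open, on these data alone, is whether an amine, a carboxylic acid or a longer chain on this carbonyl carbon would shift the value clearly beyond the scatter.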